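The source may report more compounds than this note shows. Statements on the series, on what has been measured and on what is new or still open speak of the compounds shown alone.

Series notes. The shared core of compound 1 `CN(CC1=CC[C@H]2C[C@@H]1C2(C)C)Cc1ccc(-c2cccc(F)c2)cc1` carries a biaryl arm. In an assay on HEK293 cells for displacement of a labelled ligand from C-X-C chemokine receptor type 3 (Homo sapiens) (a higher number here means a weaker inhibitor, a lower number a stronger inhibitor), compound 1 gives 2510 nM. Compound 2 `CN(CC1=CC[C@H]2C[C@@H]1C2(C)C)Cc1ccc(-c2ccc(C(F)(F)F)cc2)cc1` reaches only a limit in this assay, > 316 nM. Compound 3 `CC(=O)c1cccc(-c2ccc(CN(C)CC3=CC[C@H]4C[C@@H]3C4(C)C)cc2)c1` likewise stands at a limit in this assay, > 316 nM, so its place among the numbers is open. The step from fluoro to acetyl is therefore not readable, a step that the limit leaves unreadable from compound 1 to compound 3, as the limit of > 316 nM in this assay, at which 2 of the 3 values shown sit, shows. Compound 4 `CN(CC1=CC[C@H]2C[C@@H]1C2(C)C)Cc1ccc(-c2ccc(Cl)cc2)cc1` differs from compound 3 by 4-chlorophenyl in place of 3-acetylphenyl on an aromatic carbon. Among the compounds with values here, no measured step bears directly on this change, and both halogen analogues so far sit weak or at a limit. Compound 4 is expected near 3000 nM in this assay, within 500 nM to 15000 nM, a step that the limit leaves unreadable from compound 3 to compound 4 that is only an estimate.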

Compound 4, inhibition constant: > 316 nM
Compound 4 gave a limit, no number (the forecaster's own chance of this, stated with the estimate: 55%); the middle value does not contradict the limit.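

Compound 4 gives only a limit, so no step linking it to compound 1, compound 2 or compound 3 can be read: the limit of > 316 nM in this assay, at which 3 of the 4 values shown sit.

Still open, going by these compounds, is where compound 2, compound 3 and compound 4 stand relative to compound 1, and whether any of these changes on the biaryl arm shifts the inhibition constant.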